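The source may report more compounds than this note shows. Statements on the series, on what has been measured and on what is new or still open speak of the compounds shown alone.

Compound 1 `Cc1ccc(OCC(=O)N(Cc2cccs2)C2CCCCC2)cc1` was tested in an assay on HEK293 cells for agonist activity at transient receptor potential cation channel subfamily M member 8 (Homo sapiens), read by fluorescence and calcium flux, with a stated time of 15 min (on this read-out lower numbers stand for an effect already at smaller amounts and higher numbers for an effect only at larger amounts of compound), and gives 40000 nM there. Of the two numbers recorded so far, this is the highest one: compound 2 `CCN(Cc1nccs1)C(=O)COc1ccc(C)cc1` gives 3060 nM in this assay, a markedly lower number that lies beyond the usual scatter. Compound 2 differs from compound 1 in more than one place, so its value shows only where a related compound can land, not what any single change does.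

Compound 3 `C=CCN(Cc1cccs1)C(=O)COc1ccc(C)cc1` has not yet been measured in this assay. It differs from compound 1 in a single place: allyl in place of cyclohexyl on an amide-type nitrogen. Among the measured compounds shown here, no step between measured compounds shows what this particular exchange does on its own. Still, compound 2, which also carries no ring on its amide-type nitrogen, gives 3060 nM, and that suggests a lower number is reachable once the cyclohexyl is gone. Compound 3 is therefore expected to reach about 8000 nM, with a range from 2500 nM to 25000 nM. This amounts to an estimated step of a 5.0-fold lower number from compound 1 to compound 3 (0.70 log units; beyond the scatter), toward a lower number and beyond the scatter.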

Compound 3, half-maximal effective concentration: 20 nM
Beside the measured number, compound 3's estimate is 400-fold (2.60 log units) above it; measured number outside the range, below it.
By their numbers in this assay, from the lowest: compound 3; then compound 2; then compound 1.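

In this assay, the group on the amide-type nitrogen proves to be a decisive position: with the rest of the molecule unchanged, putting allyl in place of cyclohexyl gives a 2000-fold lower number from compound 1 to compound 3 (3.30 log units; beyond the scatter) and this single change is a large one, well beyond the scatter. Compound 2 differs from compound 1 in more than one place and could only hint that lower numbers were reachable, whereas this pair ties a very large shift to one exchange at one position. Nothing available here explains the size of the step, so it cannot be said whether it goes with losing the ring, with having fewer heavy atoms or with gaining the double bond.

The compounds shown leave open which of these differences counts, and a plain propyl group on the same nitrogen would separate the double bond from the loss of the ring. Also open, on these data alone, are whether a longer chain such as butyl, or a chain ending in an amine, would give a lower or higher number, and whether allyl has a similar effect when the rest of the molecule differs.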